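The source may report more compounds than this note shows. Statements on the series, on what has been measured and on what is new or still open speak of the compounds shown alone.

Compound 1 `C#CCNC(=O)Nc1ccc(-c2nc3n(Cc4c(F)cccc4F)cc(C(=O)OCC)c(=O)n3c2CN(C)Cc2ccccc2)cc1`: 676 nM in a functional assay on CHO cells for antagonist activity at Gonadotropin-releasing hormone receptor (Homo sapiens), read by a luciferase reporter, with a stated time of 30 min; on this read-out lower numbers stand for stronger inhibition and higher numbers for weaker inhibition
Compound 2 `CCNC(=O)Nc1ccc(-c2nc3n(Cc4c(F)cccc4F)cc(C(=O)OCC)c(=O)n3c2CN(C)Cc2ccccc2)cc1`: 70.8 nM
Compound 3 `CCOC(=O)c1cn(Cc2c(F)cccc2F)c2nc(-c3ccc(NC(=O)NCc4cn(CCN=[N+]=[N-])nn4)cc3)c(CN(C)Cc3ccccc3)n2c1=O`: 2570 nM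

Compound 3 gives the highest number of the three; the steps of a 3.8-fold higher number from compound 1 to compound 3 (0.58 log units; beyond the scatter) and a 36-fold higher number from compound 2 to compound 3 (1.56 log units; beyond the scatter) both lie beyond the scatter. Compound 4 `CCOC(=O)c1cn(Cc2c(F)cccc2F)c2nc(-c3ccc(NC(=O)NCc4cn(CCOCCN=[N+]=[N-])nn4)cc3)c(CN(C)Cc3ccccc3)n2c1=O` differs from compound 3 by 2-azidoethoxy in place of azido on a saturated chain carbon, two bonds along the chain from an aromatic nitrogen. Among the compounds with values here, no measured step touches this position: the steps of a 9.5-fold lower number from compound 1 to compound 2 (0.98 log units; beyond the scatter), a 3.8-fold higher number from compound 1 to compound 3 (0.58 log units; beyond the scatter) and a 36-fold higher number from compound 2 to compound 3 (1.56 log units; beyond the scatter) all concern the group on a saturated chain carbon bound to an amide-type nitrogen, where each enlargement raised the number. For the present change there is no direct guide, so only a small step in this assay is expected, if any beyond the scatter, leaning toward a higher number. Compound 4 is estimated at 3200 nM (range 1100 nM to 9500 nM), a step of a 1.2-fold higher number from compound 3 to compound 4 (0.10 log units; within the scatter).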

Compound 4, half-maximal inhibitory concentration: 3630 nM
The estimate for compound 4 lay 1.1-fold (0.05 log units) below the measured number; the measured number falls inside the stated range.
By their numbers in this assay, from the lowest: compound 2; then compound 1; then compounds 3 and 4 (each within the scatter of the next).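

On a saturated chain carbon, two bonds along the chain from an aromatic nitrogen, 2-azidoethoxy in place of azido gives a 1.4-fold higher number from compound 3 to compound 4 (0.15 log units; within the scatter) in this assay. This place therefore accepts the larger group with no step beyond the scatter, whereas the earlier step of a 3.8-fold higher number from compound 1 to compound 3 (0.58 log units; beyond the scatter), on the saturated chain carbon bound to an amide-type nitrogen, lies beyond it. Nothing available here accounts for this result. Open, on these data alone, is whether an amine or a carboxylic acid in place of azido, or a longer chain, would also stay within the scatter of compound 3.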